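Trading 4-Bromophenyl for 2,3-Dichlorophenyl

The source may hold more compounds than are shown below. What is called first, only, known or untested is meant among the compounds shown, and "the series" means these compounds.

In a functional assay on HCT-116 cells (Homo sapiens) for antiproliferative activity, read by sulforhodamine B assay, with a stated time of 48 h (on this read-out higher numbers stand for weaker inhibition and lower numbers for stronger inhibition), compound 1 (`COc1cc(O)c(C(=O)/C=C/c2cccc(Cl)c2Cl)c(OC)c1`) gives 2700 nM and compound 2 (`COc1cc(OC)c(C(=O)/C=C/c2ccc(Br)cc2)c(OCC=C(C)C)c1`) gives 2100 nM so these two numbers stand within the usual scatter of each other. Compound 3 (`COc1cc(OC)c(C(=O)/C=C/c2cccc(Cl)c2Cl)c(OCC=C(C)C)c1`) is compound 2 with one change: 2,3-dichlorophenyl in place of 4-bromophenyl on a double-bonded chain carbon bound to a double-bonded chain carbon. Compound 1 also carries 2,3-dichlorophenyl and gives 2700 nM in this assay so no shift beyond the scatter is expected in either direction. The expected step of a 1.1-fold higher number from compound 2 to compound 3 (0.06 log units; within the scatter) is small. For compound 3 the estimated value is 2400 nM (1000 nM to 5500 nM).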

Compound 3, half-maximal inhibitory concentration: 1900 nM
For compound 3 the middle estimate is 1.3-fold (0.10 log units) above the measured one; measured number inside the range.
By their numbers in this assay, from the lowest: compounds 3, 2 and 1 (each within the scatter of the next).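

In this assay, 2,3-dichlorophenyl in place of 4-bromophenyl gives a 1.1-fold lower number from compound 2 to compound 3 (0.04 log units; within the scatter) and so leaves the two groups indistinguishable at this place on the chain. Similarly, 3-methylbut-2-en-1-yl in place of hydrogen on an oxygen on an aromatic ring gives a 1.4-fold lower number from compound 1 to compound 3 (0.15 log units; within the scatter) and so also stays within the scatter. There is no evidence here to explain why either change has so little effect. Still open, from the compounds shown here alone, is whether an amine or a carboxylic acid on the phenyl ring, or a longer chain on that oxygen, would move the number beyond the scatter.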